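The source may hold more compounds than are shown below. What is called first, only, known or untested is meant among the compounds shown, and "the series" means these compounds.

Among the compounds with values here, compound 1 `COc1ccc2c(c1)c(-c1cc(C(F)(F)F)ccn1)cn2S(=O)(=O)c1ccc(C)cc1` stands at the lower of the two numbers measured so far: in a functional assay on A549 cells (Homo sapiens) for inhibition, tested at 10 uM (a higher number here means a stronger effect of the compound at the concentration tested, a lower number a weaker effect), compound 1 gives 9.9%. Within the data shown here, the only other measured compound, compound 2 `COc1ccc2c(c1)c(-c1cc(C(F)(F)F)cc(-c3cn(S(=O)(=O)c4ccc(C)cc4)c4ccc(OC)cc34)n1)cn2S(=O)(=O)c1ccc(C)cc1`, gives 22.2% in this assay, a gap beyond the usual scatter; the two structures differ in more than one place, so the pair shows no single step. Compound 3 `Cc1ccc(S(=O)(=O)n2cc(-c3cc(C(F)(F)F)ccn3)c3cc(Br)ccc32)cc1` is to be measured in this assay. It differs from compound 1 by bromo in place of methoxy on an aromatic carbon. Among the measured compounds shown here, no measured pair resembles this change, and it is expected to bring a number 2.1 percentage points higher from compound 1 to compound 3 (within the scatter), nothing beyond the scatter in either direction. Compound 3 is estimated at 12%, within a range from 0% to 30%.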

Compound 3, a percentage reported as inhibition, at one concentration (the size of the read-out at that concentration, not a potency): 20.6%
Beside the measured number, compound 3's estimate is 8.6 percentage points below it; the range from low to high includes it.
By their numbers in this assay, from the lowest: compound 1; then compounds 3 and 2 (each within the scatter of the next).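

In this assay, bromo in place of methoxy on an aromatic carbon of the shared core gives a number 10.7 percentage points higher from compound 1 to compound 3 (beyond the scatter). Within the data shown here, this is the first single change that can be read, and it shows that the read-out responds to the group at this position, though the step is modest. Nothing available explains this step. The compounds shown leave open what an amine or a carboxylic acid would give at this position. They also leave open whether the same change would have a similar effect in compound 2.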